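The compounds below may be only part of what the source reports. "The series", "measured", "known", "first", "only" and "open" are said of these compounds alone.

Series notes. The shared core of compound 1 `COc1cc(-c2nn(-c3cccc(NC(=O)c4cccc(C(F)(F)F)c4)c3)cc2-c2ccncc2)ccc1Cl` is carried through compound 2 `COc1cc(-c2nn(-c3cccc(NC(=O)Nc4cccc(C(F)(F)F)c4)c3)cc2-c2ccncc2)ccc1Cl` and compound 3 `COc1cc(-c2nn(-c3cccc(NC(=O)Nc4ccc(Cl)c(C(F)(F)F)c4)c3)cc2-c2ccncc2)ccc1Cl`, which differ only in the group on the carbonyl carbon. In a functional assay on A549 cells (Homo sapiens) for inhibition, read by sulforhodamine B assay, with a stated time of 48 h (a lower number here means a stronger inhibitor of growth, a higher number a weaker inhibitor of growth), compound 1 gives 1870 nM, compound 2 gives 794 nM and compound 3 gives 1020 nM. The step of a 2.4-fold lower number from compound 1 to compound 2 (0.37 log units; beyond the scatter) is the only one beyond the scatter; a 1.8-fold lower number from compound 1 to compound 3 (0.26 log units; within the scatter) and a 1.3-fold higher number from compound 2 to compound 3 (0.11 log units; within the scatter) are not. Compound 3 therefore stands second highest of the three numbers, within the scatter of both compound 2 and compound 1.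

Compound 4 `COc1cc(-c2nn(-c3cccc(NC(=O)c4ccccc4)c3)cc2-c2ccncc2)ccc1Cl` is the next point. Relative to compound 3 the change is phenyl in place of (4-chloro-3-(trifluoromethyl)phenyl)amino on a carbonyl carbon. For the measured compounds named here, no measured pair covers this exact change. The closest guide is compound 1, which also carries an aryl directly on the carbonyl carbon, and the step of a 1.8-fold lower number from compound 1 to compound 3 (0.26 log units; within the scatter) ran in the opposite direction, within the scatter; compound 4 in addition loses the trifluoromethyl and the chlorine. In this assay a number close to that of compound 1, or somewhat higher, is therefore expected for compound 4, meaning a step of a 2.9-fold higher number from compound 3 to compound 4 (0.47 log units; beyond the scatter) that may not clear the scatter. Compound 4 is estimated at 3000 nM, with a range of 1200 nM to 8000 nM.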

Compound 4, concentration for 50% growth inhibition: 585 nM
Beside the measured number, compound 4's estimate is 5.1-fold (0.71 log units) above it; the measured number lies below the stated range.
By their numbers in this assay, from the lowest: compounds 4, 2, 3 and 1 (each within the scatter of the next, the first and the last beyond it).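

For the compounds shown here, on the carbonyl carbon, the trifluoromethyl is not needed for growth inhibition in this assay: with hydrogen in its place, the record shows a 3.2-fold lower number from compound 1 to compound 4 (0.50 log units; beyond the scatter) and is the clearest step so far, with compound 4 as the only compound whose distance from compound 1 is that large. The amide-type link also looks less decisive than the step from compound 1 to compound 2 alone suggested, since the plain phenyl of compound 4 cannot be separated from either (3-(trifluoromethyl)phenyl)amino or (4-chloro-3-(trifluoromethyl)phenyl)amino, with a 1.4-fold lower number from compound 2 to compound 4 (0.13 log units; within the scatter) and a 1.7-fold lower number from compound 3 to compound 4 (0.24 log units; within the scatter) both read as no real difference. Nothing on hand explains why the smaller group with no hydrogen-bond donor performs on a par with these two larger groups.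

Still open, as far as these compounds go, is whether the unsubstituted phenylamino group on the carbonyl carbon would match compound 4, which would separate the effect of the amino link from that of the ring substituents. Also open, from the compounds shown here alone, is how far the phenyl itself can be changed, for example by a carboxylic acid or a dimethylamino group on the ring, or by a benzyl group or a longer alkyl chain in its place.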